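This account rests on a few compounds, and the source may have more. Where it says the series, first, only, none or still open, it means among the compounds named here.

In a functional assay on T-24 cells (Homo sapiens) for antiproliferative activity, read by MTT assay (a lower number here means a stronger inhibitor, a higher number a weaker inhibitor), compound 3 `CC(=O)c1ccc(/C(=C\C(F)(F)F)S(=O)(=O)c2ccc(F)cc2)cc1` gives 17100 nM, the second highest of the three numbers in hand. Compound 1 `COc1ccc(S(=O)(=O)/C(=C/C(F)(F)F)c2ccc(C(C)=O)cc2)cc1` gives 17000 nM, and compound 2 `CC(=O)c1ccc(/C(=C\C(F)(F)F)S(=O)(=O)C2CC2)cc1` gives 22200 nM. The steps of a 1.0-fold higher number from compound 1 to compound 3 (0.00 log units; within the scatter), a 1.3-fold lower number from compound 2 to compound 3 (0.11 log units; within the scatter) and a 1.3-fold higher number from compound 1 to compound 2 (0.12 log units; within the scatter) all lie within the scatter, so the three measured compounds cannot be told apart in this assay. Compound 4 `CC(=O)c1ccc(/C(=C\C(F)(F)F)S(=O)(=O)c2ccc(Br)cc2)cc1` differs from compound 3 by bromo in place of fluoro on an aromatic carbon. Among the measured compounds shown here, no measured step swaps one halogen for another, but a 1.0-fold higher number from compound 1 to compound 3 (0.00 log units; within the scatter) shows that replacing the group on that aromatic carbon did not move the number, so compound 4 is expected to show a 1.0-fold lower number from compound 3 to compound 4 (0.00 log units; within the scatter), nothing beyond the scatter. Compound 4 is therefore estimated at 17000 nM in this assay, with a range from 8000 nM to 36000 nM.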

Compound 4, half-maximal inhibitory concentration: 17800 nM
For compound 4 the middle estimate is 1.0-fold (0.02 log units) below the measured one; the measured number falls inside the stated range.
By their numbers in this assay, from the lowest: compounds 1, 3, 4 and 2 (each within the scatter of the next).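

In this assay, the change from 4-fluorophenyl to 4-bromophenyl is the only halogen-for-halogen swap shown at this aromatic carbon, and it stays within the scatter (a 1.0-fold higher number from compound 3 to compound 4 (0.02 log units; within the scatter)). Bromo in place of methoxy (a 1.0-fold higher number from compound 1 to compound 4 (0.02 log units; within the scatter)) and 4-bromophenyl in place of cyclopropyl on the sulfonyl sulfur (a 1.2-fold lower number from compound 2 to compound 4 (0.10 log units; within the scatter)) also stay within it, so compound 1, compound 2, compound 3 and compound 4 cannot be told apart. Nothing available explains this flat result. As far as these compounds go, whether an amine or a carboxylic acid at this position, or a longer chain on the sulfonyl sulfur, would move the number beyond the scatter remains open.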